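The source may hold more compounds than are shown below. What is called first, only, known or untested is meant among the compounds shown, and "the series" means these compounds.

The series shares one steroid-like core and a triazole arm, and it is followed in a functional assay on A549 cells (Homo sapiens) for cytotoxicity, read by MTT assay, with a stated time of 4 days; a higher number here means a weaker inhibitor, a lower number a stronger inhibitor. Compound 1 `C=C1C[C@]23C[C@@]1(O)CC[C@H]2c1ccc(OS(=O)(=O)c2ccc(C)cc2)c(C)c1[C@@H]3Cn1cc(-c2ccc(OC)cc2)nn1` carries a (4-methylphenyl)sulfonyl on the phenolic oxygen and a 4-methoxyphenyl on the triazole. In this assay compound 1 gives only a limit, > 20000 nM. Compound 2 `C=C1C[C@]23C[C@@]1(O)CC[C@H]2c1ccc(O)c(C)c1[C@@H]3Cn1cc(-c2ccc(OC)cc2)nn1` has the free phenol; in this assay compound 2 likewise gives only a limit, > 20000 nM. The step that the two limits leave unreadable from compound 1 to compound 2 therefore cannot be sized. Compound 3 `Cc1c(O)ccc2c1[C@H](Cn1cc(-c3ccc(F)cc3)nn1)[C@@]13CC(=O)[C@@](C)(CC[C@@H]21)C3` has a different core but the same 4-fluorophenyl on the triazole that compound 4 will carry. In this assay compound 3 also gives only a limit, > 20000 nM. All three values sit at the limit of > 20000 nM in this assay, at which 3 of the 3 values shown sit, so compound 1 stands at the limit together with everything measured.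

Compound 4 `C=C1C[C@]23C[C@@]1(O)CC[C@H]2c1ccc(OS(=O)(=O)c2ccc(C)cc2)c(C)c1[C@@H]3Cn1cc(-c2ccc(F)cc2)nn1` differs from compound 1 by fluoro in place of methoxy on an aromatic carbon. Within the data shown here, no measured step bears directly on this exchange; the one readable pair is unreadable, and compound 3 shows only that a 4-fluorophenyl arm on another core stays at the limit. A step of no readable size is therefore expected, and the value is most likely to come back as a limit again.

Compound 4 is thus estimated at 30000 nM, within 15000 nM to 100000 nM, corresponding to an expected step that the limit leaves unreadable from compound 1 to compound 4.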

Compound 4, half-maximal inhibitory concentration: > 20000 nM
Compound 4 gave a limit, no number; the forecaster's own chance of this, stated with the estimate: 80%; the middle value lies beyond the limit too.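

In this assay compound 4 gives > 20000 nM as a limit and not a number. Among these compounds, compound 1 also gives only a limit, so no step from methoxy to fluoro can be read between compound 1 and compound 4. The compounds shown leave open whether the group on the triazole arm matters at all in this assay for this series: the limit of > 20000 nM in this assay, at which 4 of the 4 values shown sit.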